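Taking the sulfamoyl group off compound 3

The source may report more compounds than this note shows. Statements on the series, on what has been measured and on what is new or still open speak of the compounds shown alone.

In a functional assay on RKO cells (Homo sapiens) for cytotoxicity, read by resazurin assay, with a stated time of 72 h (on this read-out higher numbers stand for weaker inhibition and lower numbers for stronger inhibition), compound 3 `Cc1nc2ccccc2n1-c1csc(Nc2ccc(S(N)(=O)=O)cc2)n1` gives 45000 nM and sits level, within the scatter, with compound 1 `Cc1nc2ccccc2n1-c1csc(Nc2cccc(Br)c2)n1` at 36000 nM on the same scale. Both stand far from compound 2 `Cc1nc2ccccc2n1-c1csc(Nc2ccc(Br)cc2)n1` at 90 nM in this series.

Among the measured compounds shown here, compound 4 `Cc1nc2ccccc2n1-c1csc(Nc2ccccc2)n1` has hydrogen in place of sulfamoyl on an aromatic carbon of a six-membered aromatic ring of carbon only, para to a large group hydrogen in place of sulfamoyl on an aromatic carbon and this is the only change.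

For the measured compounds named here, two measured steps bear on it. The closer one is a 500-fold higher number from compound 2 to compound 3 (2.70 log units; beyond the scatter) with sulfamoyl entering in place of bromo on an aromatic carbon. The other is a 400-fold lower number from compound 1 to compound 2 (2.60 log units; beyond the scatter) with 4-bromophenyl in place of 3-bromophenyl, so bromo alone can give either end of the range seen here. Neither step shows what a hydrogen does at this place, and the data hold no direct comparison.

Compound 4 is expected to move toward compound 2 only part of the way, given the size of a 500-fold higher number from compound 2 to compound 3 (2.70 log units; beyond the scatter) in the series. The expected change is a 15-fold lower number from compound 3 to compound 4 (1.18 log units; beyond the scatter) and it remains uncertain. For compound 4 the estimated value is 3000 nM with an expected range of 300 nM to 30000 nM in this assay as well.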

Compound 4, half-maximal inhibitory concentration: 40000 nM
Beside the measured number, compound 4's estimate is 13-fold (1.12 log units) below it; measured number above the stated range.
By their numbers in this assay, from the lowest: compound 2; then compounds 1, 4 and 3 (each within the scatter of the next).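

In this assay hydrogen in place of sulfamoyl gives a 1.1-fold lower number from compound 3 to compound 4 (0.05 log units; within the scatter) and so, on this aromatic carbon, the two read level and the sulfamoyl group shows no measurable cost against the unsubstituted ring. The number of compound 3 therefore reflects the loss of bromo and not anything added by sulfamoyl. Hydrogen in place of bromo gives a 440-fold higher number from compound 2 to compound 4 (2.65 log units; beyond the scatter) and yet a 1.1-fold higher number from compound 1 to compound 4 (0.05 log units; within the scatter) when the bromo belongs to the 3-bromophenyl, so among these compounds the low number goes with the 4-bromophenyl alone and not with bromo as such. Nothing available on these compounds accounts for this difference.

Left open is whether the low number is particular to bromo or extends to other groups on the same aromatic carbon, such as chloro, methyl, methoxy or an amine. Also open, as far as these compounds go, is whether the number of compound 2 at 90 nM holds when the shared core carries something else, such as an ethyl chain in place of its methyl.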